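A few compounds are considered here, and "the series" means these few. Any claim that something is new, unique, unknown or untested is made for them only; others in the source may bear on it.

Measured so far in a physicochemical assay for lipophilicity, at pH 7.4; on this read-out lower numbers stand for lower lipophilicity and higher numbers for higher lipophilicity:
- compound 1 `N=S1(=O)c2ccccc2C(=O)N1c1ccccc1`: 1.3
- compound 2 `NC1=NS(=O)(=O)c2ccccc21`: 0.2
- compound 3 `CCN1C(=O)c2ccccc2S1(=O)=O`: "not determined" (no result reported)

Compound 1 carries the higher of the two numbers recorded in this assay. Its nearest neighbour is compound 2, which lies lower by a gap beyond the usual scatter. Compound 3 is part of the series but has no number in this assay. For the measured compounds named here, no pair of measured compounds differs in one place only, so no measured single-point step is available as a reference.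

Compound 4 `CCN1C(=O)c2ccccc2S1(=N)=O` is the next compound to be measured in this assay. It differs from compound 1 in one place: ethyl in place of phenyl on an amide-type nitrogen in a ring. Going by the values given here, no measured pair shows this exchange, so the expectation rests on the structural change alone. The step is expected to run downward and to be larger than the scatter. The expected step is a number 0.90 log units lower from compound 1 to compound 4 (beyond the scatter) in this assay. For compound 4 the expected value in this assay is 0.4, with a range from -0.2 to 1.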

Compound 4, distribution coefficient: 0.7
Beside the measured number, compound 4's estimate is 0.30 log units below it, within the range that was stated.
By their numbers in this assay, from the lowest: compound 2; then compound 4; then compound 1.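

Ethyl in place of phenyl on an amide-type nitrogen in a ring, next to the ring sulfur, gives the first measured single-point step in the series: in this assay the exchange reads a number 0.60 log units lower from compound 1 to compound 4 (beyond the scatter) and counts as modest. For the compounds shown here, the read-out at this position thus responds to the exchange by more than the usual scatter, although a single pair describes only this one change on the core of compound 1. Nothing on hand accounts for the size of the step.

The compounds shown leave open whether the read-out follows the size of the group on this nitrogen, which a methyl, a longer chain such as butyl, or a benzyl group would help to settle. They also leave open how an amine or a carboxylic acid carried on such a chain would read at this position in this assay.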